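The compounds below may be only part of what the source reports. "The series", "measured", "known", "first", "only" and "open" are said of these compounds alone.

For the measured compounds named here, in a functional assay on HL-60 cells (Homo sapiens) for cytotoxicity, read by ELISA, with a stated time of 2 days (on this read-out lower numbers stand for stronger inhibition and higher numbers for weaker inhibition), three compounds on a shared core have numbers so far. Compound 1 `Oc1cccc(-c2cc(-c3ccccc3)cc(-c3ccccc3)n2)c1` reads 11500 nM there. Compound 2 `Oc1cccc(-c2cc(-c3ccccc3)cc(-c3ccsc3)n2)c1` reads 10300 nM there. Compound 3 `Oc1ccc(-c2cc(-c3ccccc3)cc(-c3ccccc3)n2)cc1` reads 1400 nM as the lowest number of the three, well apart from the other two.

Compound 4 `Oc1ccc(-c2cc(-c3ccccc3)cc(-c3ccsc3)n2)cc1` has not been measured. It keeps the 4-hydroxyphenyl group of compound 3 and differs in one place, with thiophen-3-yl in place of phenyl next to the ring nitrogen: thiophen-3-yl in place of phenyl on an aromatic carbon is the full count of that change.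

The nearest evidence is the same exchange made with 3-hydroxyphenyl in place of 4-hydroxyphenyl, which gave a 1.1-fold lower number from compound 1 to compound 2 (0.05 log units; within the scatter) and so no real change. The other measured step gave an 8.2-fold lower number from compound 1 to compound 3 (0.91 log units; beyond the scatter) on going from 3-hydroxyphenyl to 4-hydroxyphenyl. Compound 4 already carries that group, so compound 3 is the natural starting point. Going by these compounds, one pair is thin evidence, and whether the exchange behaves alike with 4-hydroxyphenyl present is untested.

In this assay no step beyond the scatter is therefore expected, and the estimate is a 1.1-fold lower number from compound 3 to compound 4 (0.03 log units; within the scatter) for this change. Compound 4 is estimated at 1300 nM with an expected range from 550 nM to 3000 nM on this evidence.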

Compound 4, half-maximal inhibitory concentration: 3600 nM
Compound 4: the middle estimate sits 2.8-fold (0.44 log units) below what was measured, outside the stated range (above it).
By their numbers in this assay, from the lowest: compound 3; then compound 4; then compounds 2 and 1 (each within the scatter of the next).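

Thiophen-3-yl in place of phenyl at this position, next to the ring nitrogen, is not a neutral exchange on every core: in this assay it gives a 2.6-fold higher number from compound 3 to compound 4 (0.41 log units; beyond the scatter), so its effect differs with the hydroxyphenyl group present: the same change on two cores in this assay, a 1.1-fold lower number (0.05 log units; within the scatter) from compound 1 to compound 2 and a 2.6-fold higher number (0.41 log units; beyond the scatter) from compound 3 to compound 4, 2.9-fold (0.46 log units) apart, beyond the scatter of two such steps Seen from the other side, 4-hydroxyphenyl in place of 3-hydroxyphenyl still helps when thiophen-3-yl is present, with a 2.9-fold lower number from compound 2 to compound 4 (0.46 log units; beyond the scatter), but the gain is smaller than on the phenyl core: the same change on two cores in this assay, an 8.2-fold lower number (0.91 log units; beyond the scatter) from compound 1 to compound 3 and a 2.9-fold lower number (0.46 log units; beyond the scatter) from compound 2 to compound 4, 2.9-fold (0.46 log units) apart, beyond the scatter of two such steps Together, the four compounds show that the two changes do not simply add up, so a step measured on one core cannot be carried over unchanged to the other.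

The compounds shown leave open whether a methoxy group or an amine in place of the hydroxyl of the 4-hydroxyphenyl group would keep the lower number of compound 3. They also leave open whether the same dependence between the two places would appear with an amine or a carboxylic acid on the phenyl group that sits at the position being exchanged.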